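Rat plasma half-life of a nitrooxymethyl analogue

The compounds below may be only part of what the source reports. "The series", "measured", "known", "first", "only" and "open" are said of these compounds alone.

Of the compounds shown here, three that share one core have been measured in an ADME assay on a cell-free system (plasma, Homo sapiens) for metabolic stability, with Plasma (Rattus norvegicus) as the target, read by HPLC, at pH 7.4; on this read-out higher numbers stand for a longer-lived compound and lower numbers for a shorter-lived compound. Compound 1 `CC(=O)Oc1ccccc1C(=O)O[C@H]1CO[C@H]2[C@@H]1OC[C@H]2OC(=O)c1cccc(C)c1` gives 0.165 h. Compound 2 `CC(=O)Oc1ccccc1C(=O)O[C@H]1CO[C@H]2[C@@H]1OC[C@H]2OC(=O)c1ccc(C)cc1` gives 0.105 h in this assay, and compound 3 `CC(=O)Oc1ccccc1C(=O)O[C@H]1CO[C@H]2[C@@H]1OC[C@H]2OC(=O)c1ccc(C#N)cc1` gives 0.0888 h. The steps among them are small: a 1.6-fold lower number from compound 1 to compound 2 (0.20 log units; within the scatter), a 1.9-fold lower number from compound 1 to compound 3 (0.27 log units; within the scatter) and a 1.2-fold lower number from compound 2 to compound 3 (0.07 log units; within the scatter). Compound 3 therefore stands within the scatter of both companions, and the three numbers cannot be told apart.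

Compound 4 `CC(=O)Oc1ccccc1C(=O)O[C@H]1CO[C@H]2[C@@H]1OC[C@H]2OC(=O)c1ccc(CO[N+](=O)[O-])cc1` has not yet been measured. It differs from compound 3 in one place: (nitrooxy)methyl in place of cyano on an aromatic carbon. Among the compounds with values here, no measured step introduces a group of this kind, so the nearest bearing comes from a 1.2-fold lower number from compound 2 to compound 3 (0.07 log units; within the scatter) and a 1.9-fold lower number from compound 1 to compound 3 (0.27 log units; within the scatter), both within the scatter, which show that exchanging one small substituent on that ring for another left the half-life essentially where it was. On that basis no step beyond the scatter is expected in this assay, and the estimated step of a 1.0-fold higher number from compound 3 to compound 4 (0.01 log units; within the scatter) is expected to be small. Compound 4 is expected to give 0.09 h in this assay, with a range from 0.04 h to 0.2 h.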

Compound 4, half-life: 0.1 h
Compound 4: the middle estimate sits 1.1-fold (0.05 log units) below what was measured, within the range that was stated.
By their numbers in this assay, from the lowest: compounds 3, 4, 2 and 1 (each within the scatter of the next).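

In this assay, (nitrooxy)methyl, with 5 heavy atoms and 3 hydrogen-bond acceptors, replaces cyano, with 2 heavy atoms and 1 acceptor, on the aromatic carbon para to a large group, and the number stays within the scatter (a 1.1-fold higher number from compound 3 to compound 4 (0.05 log units; within the scatter)). The same holds when nitrooxy replaces hydrogen on the saturated chain carbon bound to that ring (a 1.1-fold lower number from compound 2 to compound 4 (0.02 log units; within the scatter)) and when 4-((nitrooxy)methyl)phenyl replaces 3-methylphenyl on the carbonyl carbon (a 1.7-fold lower number from compound 1 to compound 4 (0.22 log units; within the scatter)), so this position has now taken a clearly larger group, as well as methyl and cyano, without any step beyond the scatter. No measurement here bears on why the half-life stays put across these changes.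

The compounds shown leave open whether an amine, a carboxylic acid or a longer chain carrying the nitrooxy group at this position would also stay within the scatter. All four compounds also share the rest of the molecule, so they do not show whether a change outside this ring would move the number.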